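Swapping an Amide for a Sulfonyl on a Shared Core

The source may report more compounds than this note shows. Statements on the series, on what has been measured and on what is new or still open speak of the compounds shown alone.

Compound 1 `CCC(=O)N(C)c1ccc2[nH]c(-c3n[nH]c4ccccc34)cc2n1` and compound 2 `CN(C(=O)CCc1ccccc1)c1ccc2[nH]c(-c3n[nH]c4ccccc34)cc2n1` share one core and differ only in the group on the amide chain. In a functional assay on SMMC-7721 cells (Homo sapiens) for antiproliferative activity, read by MTT assay, with a stated time of 72 h (on this read-out higher numbers stand for weaker inhibition and lower numbers for stronger inhibition), compound 1 gives 33500 nM, and compound 2 gives 20900 nM. That change, a 1.6-fold lower number from compound 1 to compound 2 (0.20 log units; within the scatter), is within the scatter, so the two cannot be ranked. Compound 2 stands at the lower of the two numbers shown, with compound 1 its only neighbour. Compound 3 `CN(c1ccc2[nH]c(-c3n[nH]c4ccccc34)cc2n1)S(=O)(=O)c1ccc(Br)cc1` carries a different group on the same nitrogen: (4-bromophenyl)sulfonyl in place of phenethylcarbonyl on a nitrogen on an aromatic ring. No measured step covers an exchange of this kind; the one step shown, phenyl in place of hydrogen on a saturated chain carbon, was small. With no direct guide, compound 3 is expected to stay near the weak inhibition already seen, with wide uncertainty. The estimate for compound 3 in this assay is 15000 nM, between 4000 nM and 60000 nM. This expected change is a 1.4-fold lower number from compound 2 to compound 3 (0.14 log units; within the scatter).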

Compound 3, half-maximal inhibitory concentration: 11500 nM
Compound 3: the middle estimate sits 1.3-fold (0.12 log units) above what was measured, and the stated range covers the measured number.
By their numbers in this assay, from the lowest: compounds 3, 2 and 1 (each within the scatter of the next, the first and the last beyond it).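

Exchanging phenethylcarbonyl for (4-bromophenyl)sulfonyl on the nitrogen on an aromatic ring gives a 1.8-fold lower number from compound 2 to compound 3 (0.26 log units; within the scatter) in this assay and so leaves this pair unranked: a sulfonyl link here reads much like a carbonyl link carrying a phenyl ring. Among the compounds shown here, exchanging propanoyl for the same sulfonyl group gives a 2.9-fold lower number from compound 1 to compound 3 (0.46 log units; beyond the scatter) and is the first difference at this position to pass the scatter, though it remains modest. No measurement on hand explains either step.

Going by these compounds, the part played by the bromine remains open, and a plain phenylsulfonyl or a methylsulfonyl group on this nitrogen would separate it from that of the sulfonyl link itself. Also open, on these data alone, is how a urea at the same place would read.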